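Series notes: 4-iodophenyl to 4-(tert-butyl)phenyl step

The compounds below may be only part of what the source reports. "The series", "measured", "known", "first", "only" and "open" are said of these compounds alone.

Measured so far in an assay on BaF3 cells with thrombopoietin receptor (Homo sapiens) as the target, read by a luciferase reporter; a higher number here means a larger maximal response, a lower number a smaller maximal response:
compound 1 `Cc1[nH]n(C)c(=O)c1/N=N/c1c(O)cc(S(=O)(=O)O)c2ccccc12`: < 5%, a limit of the assay, not a number
compound 2 `Cc1[nH]n(C(C)(C)C)c(=O)c1/N=N/c1c(O)cc(S(=O)(=O)O)c2ccccc12`: < 5%, likewise a limit
compound 3 `Cc1[nH]n(-c2ccc(I)cc2)c(=O)c1/N=N/c1c(O)cc(S(=O)(=O)O)c2ccccc12`: 81%

Among the measured compounds shown here, compound 3 is the only compound with a number in this assay; the other two sit at a limit, (the limit of < 5% in this assay, at which 2 of the 3 values shown sit). Both measured steps lead to it: a number at least 76 percentage points higher from compound 1 to compound 3 (beyond the scatter) and a number at least 76 percentage points higher from compound 2 to compound 3 (beyond the scatter), so in this series a 4-iodophenyl on the aromatic nitrogen stands far above methyl and above tert-butyl there.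

Compound 4 `Cc1[nH]n(-c2ccc(C(C)(C)C)cc2)c(=O)c1/N=N/c1c(O)cc(S(=O)(=O)O)c2ccccc12` keeps that aryl group and changes only its substituent: tert-butyl in place of iodo on an aromatic carbon. For the measured compounds named here, no measured step touches the para position itself; the measured steps speak only for the aryl ring being present, which compound 4 retains. Going by the values given here, the step in this assay is therefore expected to stay within the scatter, in either direction, with some downside risk since the one active compound carries iodo. The estimate for compound 4 is 70%, between 35% and 95%, which means an expected step of a number 11 percentage points lower from compound 3 to compound 4 (beyond the scatter).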

Compound 4, largest response reached (reported as efficacy), in percent of the reference or control that the assay uses: 86%
For compound 4 the middle estimate is 16 percentage points below the measured one; the range from low to high includes it.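

In this assay, tert-butyl in place of iodo on the aryl ring gives a number 5 percentage points higher from compound 3 to compound 4 (within the scatter), so in this pair the response does not depend on iodo, and a carbon group of four heavy atoms serves there as well as the single iodine. The aryl ring on the nitrogen now holds with a second substituent, with a number at least 81 percentage points higher from compound 2 to compound 4 (beyond the scatter) and a number at least 81 percentage points higher from compound 1 to compound 4 (beyond the scatter), and tert-butyl gives a high response in compound 4 on the aryl ring, not directly on the nitrogen as in compound 2. The step between compound 1 and compound 2 cannot be read, since both values are limits: the limit of < 5% in this assay, at which 2 of the 4 values shown sit.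

From the compounds shown here alone, what a hydrogen, an amine or a carboxylic acid would give at this position on the aryl ring remains open. Also open, going by these compounds, is whether a benzyl group on the nitrogen could take the place of the aryl ring.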